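Para-halogen changes in a cytotoxic thioether oxadiazole series

The source may hold more compounds than are shown below. What is called first, only, known or untested is meant among the compounds shown, and "the series" means these compounds.

Compound 1 `CC(O)(CSc1ccc(F)cc1)c1nc(-c2ccc(Cl)cc2)no1` is the reference point. In a functional assay on DU-145 cells (Homo sapiens) for cytotoxicity, read by MTT assay (a lower number here means a stronger inhibitor, a higher number a weaker inhibitor), compound 1 gives 36300 nM. Compound 2 `CC(O)(CSc1ccc(F)cc1)c1nc(-c2ccccc2)no1` carries hydrogen in place of chloro on an aromatic carbon, the change (hydrogen in place of chloro on an aromatic carbon); its value in this assay is a limit of the assay, and compound 2 gives > 100000 nM. This step is an at least 2.7-fold higher number from compound 1 to compound 2 (0.44 log units; beyond the scatter), and the value of compound 2 sits at the limit of > 100000 nM in this assay, at which 1 of the 3 values shown sits.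

Compound 3 `CC(O)(CSc1ccc(Cl)cc1)c1nc(-c2ccc(Cl)cc2)no1` differs from compound 1 by chloro in place of fluoro on an aromatic carbon, the change (chloro in place of fluoro on an aromatic carbon). In this assay compound 3 gives 14500 nM, and the step is a 2.5-fold lower number from compound 1 to compound 3 (0.40 log units; beyond the scatter). Among the two compounds with a numerical value, compound 3 has the lowest number.

Compound 4 `CC(O)(CSc1ccccc1)c1nc(-c2ccc(Cl)cc2)no1` is not yet measured. It differs from compound 3 by hydrogen in place of chloro on an aromatic carbon, which is the same change as that from compound 1 to compound 2; read one bond further out it is (4-chlorophenyl)sulfanyl to phenylsulfanyl. Two earlier steps bear on it: removing the chloro from compound 1 to compound 2 gave an at least 2.7-fold higher number from compound 1 to compound 2 (0.44 log units; beyond the scatter), and replacing fluoro with chloro from compound 1 to compound 3 gave a 2.5-fold lower number from compound 1 to compound 3 (0.40 log units; beyond the scatter). Losing the chloro here is therefore expected to raise the number, with an expected step of a 3.1-fold higher number from compound 3 to compound 4 (0.49 log units; beyond the scatter). Compound 4 is expected to give about 45000 nM in this assay, between 18000 nM and 120000 nM.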

Compound 4, half-maximal inhibitory concentration: 4500 nM
Compound 4: middle estimate off by 10-fold (1.00 log units), on the high side; measured number outside the range, below it.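

In this assay, the new step is a 3.2-fold lower number from compound 3 to compound 4 (0.51 log units; beyond the scatter), so hydrogen in place of chloro does not carry over from one core to the other as a fixed step, and the earlier step does not even give its direction: the same change on two cores in this assay, an at least 2.7-fold higher number (0.44 log units; beyond the scatter) from compound 1 to compound 2 and a 3.2-fold lower number (0.51 log units; beyond the scatter) from compound 3 to compound 4, at least 8.8-fold (0.94 log units) apart, beyond the scatter of two such steps

Going by these compounds, compound 2 sits at a limit of the assay, > 100000 nM, so the earlier step gives only a bound and its true size stays unknown. The chloro leaves the 4-chlorophenyl group in the step to compound 2 but the (4-chlorophenyl)sulfanyl group in the step to compound 4, and with an 8.1-fold lower number from compound 1 to compound 4 (0.91 log units; beyond the scatter) also favouring hydrogen on the sulfanyl ring, the compounds show a dependence on where the change is made but do not show why, nor whether the other group on the core plays any part.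

The compounds shown leave open whether the lower number of compound 4 holds once its 4-chlorophenyl group also becomes phenyl. They also leave open how a methoxy group or an amine in place of the hydrogen on the phenylsulfanyl ring would read in this assay.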